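Swapping the aryl group on the carbonyl of a chalcone-like core

The compounds below may be only part of what the source reports. "The series", "measured", "known", "first", "only" and "open" are said of these compounds alone.

Measured so far:
compound 1, `COc1cc(-c2cc(/C=C/C(=O)c3ccc(N)cc3)[nH]n2)cc(OC)c1OC`: 28%
compound 2, `COc1cc(-c2cc(/C=C/C(=O)c3ccc(Cl)c(Cl)c3)[nH]n2)cc(OC)c1OC`: -8%

Both compounds share the same core and differ only in the ring attached to the carbonyl carbon. In a functional assay on HOP-92 cells (Homo sapiens) for cytotoxicity, read by sulforhodamine B assay, with a stated time of 48 h, tested at 10 uM (a higher number here means a weaker effect of the compound at the concentration tested, a lower number a stronger effect), compound 1 gives 28%, while compound 2 gives -8%, the lowest of the two numbers, lying a number 36 percentage points lower from compound 1 to compound 2 (beyond the scatter).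

Compound 3, `COc1ccc(C(=O)/C=C/c2cc(-c3cc(OC)c(OC)c(OC)c3)n[nH]2)cc1`, has not yet been measured. It differs from compound 2 in one place: 4-methoxyphenyl in place of 3,4-dichlorophenyl on a carbonyl carbon.

Among the measured compounds shown here, only one measured step bears on this change, and it is the step from compound 1 to compound 2: a swap of the ring on the carbonyl carbon that moved the number a number 36 percentage points lower from compound 1 to compound 2 (beyond the scatter). That step shows the read-out can move far when this ring is exchanged, but there is no direct measurement for a 4-methoxyphenyl at this place. An expected upward step of a number 23 percentage points higher from compound 2 to compound 3 (beyond the scatter) is therefore a guess that sits between the two measured numbers. For compound 3 the estimated value in this assay is 15%, with an expected range from -10% to 45%.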

Compound 3, a percentage reported as activity, at one concentration (the size of the read-out at that concentration, not a potency): -56%
Estimate against measurement, compound 3: 71 percentage points above, and the stated range ends above it.
By their numbers in this assay, from the lowest: compound 3; then compound 2; then compound 1.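

Exchanging the ring on the carbonyl carbon can strengthen the effect well beyond what the first pair showed: in this assay the change to 4-methoxyphenyl gives a number 48 percentage points lower from compound 2 to compound 3 (beyond the scatter) and makes compound 3 the strongest of the three at the concentration tested. Among the compounds shown here, the dichlorophenyl ring therefore does not mark the best result at this place, and a ring with no chlorine can go past it, while the comparison with the amino ring, a number 84 percentage points lower from compound 1 to compound 3 (beyond the scatter), is the largest step in the set and shows how much depends on the single group carried by this ring. The data shown give no reason for either step, so the result describes what happens and not why it happens.

Three compounds cannot show whether the methoxy group itself is what counts, and an ethoxy, a hydroxyl or a dimethylamino group on the same ring would be needed to test how narrow this preference is. The numbers also come from a single concentration in one cell line, so they rank these compounds under those conditions without giving a potency for any of them.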